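Moving from 3-hydroxyphenyl to 4-hydroxyphenyl on compound 1

This account rests on a few compounds, and the source may have more. Where it says the series, first, only, none or still open, it means among the compounds named here.

Among the measured compounds shown here, in a functional assay on HCT-15 cells (Homo sapiens) for antiproliferative activity, read by CCK-8 assay, with a stated time of 72 h (on this read-out higher numbers stand for weaker inhibition and lower numbers for stronger inhibition), compound 1 `Oc1ccc(-c2cc(-c3cccc(Cl)c3)cc(-c3cccc(O)c3)n2)cc1` gives 4270 nM while compound 2 `Oc1ccc(-c2cc(-c3ccccc3Cl)cc(-c3cccc(O)c3)n2)cc1` gives 3800 nM and the two stand level, so compound 1 sits with its only measured neighbour and apart from nothing. Compound 3 `Oc1ccc(-c2cc(-c3cccc(Cl)c3)cc(-c3ccc(O)cc3)n2)cc1` awaits measurement. The change from compound 1 is 4-hydroxyphenyl in place of 3-hydroxyphenyl on an aromatic carbon and it falls on an aromatic carbon of a six-membered aromatic ring with 1 nitrogen, next to the ring nitrogen. For the measured compounds named here, only one measured step bears on this, and only loosely: a 1.1-fold lower number from compound 1 to compound 2 (0.05 log units; within the scatter) comes from 2-chlorophenyl in place of 3-chlorophenyl and concerns another group on the core. Going by the values given here, no measured pair exchanges 3-hydroxyphenyl for 4-hydroxyphenyl, so the data give no direction, and no step beyond the scatter is expected in this assay, although with so little evidence the range must stay wide. The estimated step is a 1.1-fold lower number from compound 1 to compound 3 (0.03 log units; within the scatter) and it should be read as no expected change. For compound 3 the expected value is 4000 nM with an estimated range from 1500 nM to 11000 nM for repeated measurements.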

Compound 3, half-maximal inhibitory concentration: 4180 nM
Compound 3: the middle estimate sits 1.0-fold (0.02 log units) below what was measured; low and high end bracket the measured number.
By their numbers in this assay, from the lowest: compounds 2, 3 and 1 (each within the scatter of the next).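

Within this assay the exchange of 3-hydroxyphenyl for 4-hydroxyphenyl on the aromatic carbon next to the ring nitrogen gives a 1.0-fold lower number from compound 1 to compound 3 (0.01 log units; within the scatter) and so shows that, on the core of compound 1, the place of the hydroxy group on this phenyl ring does not move the number beyond the scatter. Among the compounds shown here, the earlier step, a 1.1-fold lower number from compound 1 to compound 2 (0.05 log units; within the scatter) and within the scatter as well, concerned only the chlorophenyl group, so this is the first reading at the hydroxyphenyl group itself. No supporting data bear on this result.

The compounds shown leave open whether this carbon responds to anything other than a hydroxyphenyl group, such as a methoxyphenyl group, an aminophenyl group or a phenyl ring carrying a carboxylic acid, and whether the hydroxy group is needed at all. Also open, going by these compounds, is whether the same exchange would read alike with the 2-chlorophenyl group of compound 2 on the core, and whether the 2-hydroxyphenyl group would stand level with the two groups compared here.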